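Chlorination step on the purine-type core, compound 2 to 4

This account rests on a few compounds, and the source may have more. Where it says the series, first, only, none or still open, it means among the compounds named here.

Three compounds of this series have numbers. In a functional assay on ACHN cells (Homo sapiens) for cytotoxicity, read by sulforhodamine B assay, with a stated time of 48 h (on this read-out higher numbers stand for lower toxicity in this test and lower numbers for higher toxicity in this test), compound 1 `ClCc1ccccc1Cn1cnc2c(Cl)nc(Cl)nc21` gives 4160 nM. Compound 2 `ClCc1cccc(Cn2cnc3ncnc(Cl)c32)c1` gives 7760 nM in this assay, and compound 3 `ClCc1cccc(Cn2cnc3c(Cl)nc(Cl)nc32)c1` gives 7240 nM. Compound 2 holds the highest of the three numbers, but its nearest neighbour, compound 3, and its furthest, compound 1, both lie within the usual scatter of it, so no ordering among the three can be read. Going by the values given here, no pair of these three differs in only one place, so no single step within the measured set is available to calibrate the change below.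

Compound 4 `ClCc1cccc(Cn2cnc3nc(Cl)nc(Cl)c32)c1` is the next member to be run in this assay. It differs from compound 2 by chloro in place of hydrogen on an aromatic carbon. Among the compounds with values here, the measured set gives no step of this kind to lean on, and compound 3, which also carries two chloro groups on its core, gives a number close to that of compound 2; the expectation is therefore no step beyond the scatter, in either direction, from compound 2 to compound 4, an expected 1.1-fold lower number from compound 2 to compound 4 (0.04 log units; within the scatter). Compound 4 is estimated at 7000 nM, with an expected range from 3500 nM to 14000 nM.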

Compound 4, concentration lethal to 50% of the cells: 4780 nM
Compound 4: the middle estimate sits 1.5-fold (0.17 log units) above what was measured; the measured number falls inside the stated range.
By their numbers in this assay, from the lowest: compounds 1, 4, 3 and 2 (each within the scatter of the next).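

In this assay, going by these compounds alone, the step at this position reads a 1.6-fold lower number from compound 2 to compound 4 (0.21 log units; within the scatter), and it is the first single-place comparison available. It shows that chloro in place of hydrogen on this aromatic carbon, between two ring nitrogen atoms and meta to a chloro group, leaves the number within the scatter of the parent compound. Compound 4 therefore adds one chlorine atom to the core with no readable change on this read-out, something compounds 1 to 3 could not show because no two of them differ in one place alone. No measurement in hand bears on the origin of this result.

From the compounds shown here alone, with chloro as the only replacement for hydrogen at this position, it remains open whether an amine, a methoxy group or a longer chain there would give a step beyond the scatter. Going by these compounds, it is also open whether chloro in place of hydrogen at this position would give a similar step on a compound carrying the side chain of compound 1.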